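Methyl in place of nitro on the ortho-benzyl ether

The compounds below may be only part of what the source reports. "The series", "measured", "known", "first", "only" and "open" are said of these compounds alone.

Measured so far in an ADME assay on Huh-5-2 cells (Homo sapiens) for cytotoxicity, read by WST assay, with a stated time of 3 days; on this read-out lower numbers stand for higher toxicity in this test and higher numbers for lower toxicity in this test:
Compound 1 `O=c1c(OCc2ccccc2Cl)c(-c2ccccc2)oc2cc(O)cc(O)c12` gives > 100000 nM, which is a limit of this assay and not a number.
Compound 2 `O=c1c(OCc2ccccc2Br)c(-c2ccccc2)oc2cc(O)cc(O)c12` gives 12000 nM.
Compound 3 `O=c1c(OCc2ccccc2[N+](=O)[O-])c(-c2ccccc2)oc2cc(O)cc(O)c12` gives 51000 nM.

Compound 3 holds the highest of the two numbers in this assay; its nearest neighbour is compound 2, and the gap a 4.3-fold higher number from compound 2 to compound 3 (0.63 log units; beyond the scatter) lies beyond the scatter. Compound 1 sits at the limit (the limit of > 100000 nM in this assay, at which 1 of the 3 values shown sits), so its place relative to compound 3 is only bounded: an at least 1.9-fold lower number from compound 1 to compound 3 (0.29 log units; that floor lies within the scatter) has a floor that lies within the scatter, while an at least 8.3-fold lower number from compound 1 to compound 2 (0.92 log units; beyond the scatter) is at least modest.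

Compound 4 `Cc1ccccc1COc1c(-c2ccccc2)oc2cc(O)cc(O)c2c1=O` differs from compound 3 by methyl in place of nitro on an aromatic carbon. Going by the values given here, none of the measured steps exchanges a nitro group for a methyl group; the three steps all concern chloro, bromo and nitro, and the two steps with a firm size in this assay, an at least 8.3-fold lower number from compound 1 to compound 2 (0.92 log units; beyond the scatter) and a 4.3-fold higher number from compound 2 to compound 3 (0.63 log units; beyond the scatter), are modest in scale. The step from compound 3 to compound 4 is therefore expected to be of no more than modest size in this assay, with no direction that can be read from the data.

Compound 4 is estimated at 50000 nM, between 15000 nM and 150000 nM, which means an expected step of a 1.0-fold lower number from compound 3 to compound 4 (0.01 log units; within the scatter).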

Compound 4, half-maximal cytotoxic concentration: 55000 nM
Estimate against measurement, compound 4: 1.1-fold (0.04 log units) below; the range from low to high includes it.
By their numbers in this assay, from the lowest: compound 2; then compounds 3 and 4 (each within the scatter of the next). At a limit, above all of these: compound 1.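

In this assay, nitro, with its 3 heavy atoms and 2 hydrogen-bond acceptors, gives way to methyl, with 1 heavy atom and no hydrogen-bond acceptors, and the two compounds cannot be told apart: a 1.1-fold higher number from compound 3 to compound 4 (0.03 log units; within the scatter) stays within the scatter, so at this place, on an aromatic carbon ortho to a large group, these two very different groups give the same reading. Bromo now stands apart from two other groups rather than one, with a 4.6-fold higher number from compound 2 to compound 4 (0.66 log units; beyond the scatter) lying beyond the scatter and close in size to a 4.3-fold higher number from compound 2 to compound 3 (0.63 log units; beyond the scatter), which makes compound 2 the one compound with a clearly lower number among those that carry a true value. Compound 1 cannot be placed firmly against compound 4, since an at least 1.8-fold lower number from compound 1 to compound 4 (0.25 log units; that floor lies within the scatter) gives only a floor and the value of compound 1 is a limit: the limit of > 100000 nM in this assay, at which 1 of the 4 values shown sits.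

Going by these compounds, whether the lower number of compound 2 belongs to bromo alone remains open, since no other group of its kind, such as iodo, stands at this place. On these data alone, what an amine, a carboxylic acid or a longer chain such as propyl would give here is also open, as is whether the same picture holds for these groups on other carbons of this ring.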